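From isobutyl to cyclopropylmethoxy, close to a limit

The source may report more compounds than this note shows. Statements on the series, on what has been measured and on what is new or still open speak of the compounds shown alone.

In a physicochemical assay for permeability, using PAMPA (a higher number here means that the compound crosses the layer faster, a lower number that the compound crosses the layer more slowly), compound 2 `CC(C)Cc1cc2oc(=O)n(CCC(=O)O)c2cc1Cl` gives < 10 nm/s, which is a limit of the assay and not a number. Compound 1 `O=C(O)CCn1c(=O)oc2cc(OCC3CCC3)c(Cl)cc21` gives 12 nm/s. Among the compounds with values here, the one measured step that bears on this is an at least 1.2-fold lower number from compound 1 to compound 2 (0.07 log units; that floor lies within the scatter), with isobutyl in place of cyclobutylmethoxy on an aromatic carbon. Compound 3 `O=C(O)CCn1c(=O)oc2cc(OCC3CC3)c(Cl)cc21` carries cyclopropylmethoxy in place of isobutyl on that carbon: cyclopropylmethoxy in place of isobutyl on an aromatic carbon. This partly reverses the measured step, which stayed within the scatter, so the expected step is small: an at least 1.1-fold higher number from compound 2 to compound 3 (0.04 log units; that floor lies within the scatter). For compound 3 the estimate is 11 nm/s, expected between 6 nm/s and 20 nm/s.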

Compound 3, apparent permeability: 19 nm/s
Compound 3: middle estimate off by 1.7-fold (0.24 log units), on the low side; the range from low to high includes it.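

In this assay, cyclopropylmethoxy in place of isobutyl on this aromatic carbon gives an at least 1.9-fold higher number from compound 2 to compound 3 (0.27 log units; that floor lies within the scatter). Compound 2 gives a limit of the assay and not a number, so this step has only a floor: the limit of < 10 nm/s in this assay, at which 1 of the 3 values shown sits. Cyclopropyl in place of cyclobutyl on the chain carbon bound to the oxygen gives a 1.6-fold higher number from compound 1 to compound 3 (0.20 log units; within the scatter), so these two rings are not told apart here. Going by these compounds, what an amine or a longer chain on this aromatic carbon would do in this assay stays open.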